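The source may report more compounds than this note shows. Statements on the series, on what has been measured and on what is new or still open speak of the compounds shown alone.

In a functional assay on cells (Platelet, Homo sapiens) for inhibition (on this read-out higher numbers stand for weaker inhibition and lower numbers for stronger inhibition), three compounds sharing one core have been measured. Compound 1, `CCOC(=O)c1ccc(-c2nn(-c3ccco3)c3ccccc23)cc1`, gives 340 nM, compound 2, `CCOC(=O)c1ccc(-c2nn(CC)c3ccccc23)cc1`, gives 360 nM, and compound 3, `COC(=O)c1ccc(-c2nn(Cc3ccccc3)c3ccccc23)cc1`, gives 560 nM. Compound 3 therefore sits within the scatter of both other compounds, and the three cannot be ranked on these numbers.

The next compound, compound 4, `NC(=O)c1ccc(-c2nn(Cc3ccccc3)c3ccccc23)cc1`, is made from compound 3 by one change: amino in place of methoxy on a carbonyl carbon. Put simply, methoxycarbonyl gives way to carbamoyl.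

Among the measured compounds shown here, only one measured step changes a single place, and it lies elsewhere in the structure: a 1.1-fold higher number from compound 1 to compound 2 (0.02 log units; within the scatter). It swaps furan-2-yl for ethyl on an aromatic nitrogen and stays within the scatter. It shows that this one swap left the number in place, but it says nothing direct about the carbonyl carbon. For the measured compounds named here, none of the measured compounds carries amino there, so the direction is a cautious judgement rather than a measured trend. A real shift beyond the scatter towards a higher number, meaning weaker inhibition, is expected, with wide uncertainty. The expected change is a 2.1-fold higher number from compound 3 to compound 4 (0.33 log units; beyond the scatter). For compound 4 the estimated value is 1200 nM, with an expected range from 300 nM to 5000 nM.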

Compound 4, half-maximal inhibitory concentration: > 10000 nM
Compound 4: no number, only a limit (the forecaster's own chance of this, stated with the estimate: 10%); at least 8.3-fold (0.92 log units) between middle value and limit.
By their numbers in this assay, from the lowest: compounds 1, 2 and 3 (each within the scatter of the next). At a limit, above all of these: compound 4.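

In this assay, the carbonyl carbon turns out to be a place where one small swap matters: amino in place of methoxy gives an at least 17-fold higher number from compound 3 to compound 4 (1.25 log units; beyond the scatter). This is the only step shown that lies beyond the scatter, whereas the earlier step, made on an aromatic nitrogen, left the number in place, so inhibition in this series depends strongly on what sits on this carbonyl carbon. Compound 4 has no number, only a limit of the assay, > 10000 nM, so the size of the step is bounded on one side and not fixed: the limit of > 10000 nM in this assay, at which 1 of the 4 values shown sits.

The swap removes methoxy, with its carbon and oxygen, and brings in amino, with a hydrogen-bond donor, and a single pair of compounds cannot show which of these differences accounts for the loss of inhibition. On these data alone, a carboxylic acid or a methylamino group on the same carbonyl carbon would help to separate them, and it remains open whether any group there keeps inhibition as well as methoxy does.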